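The compounds below may be only part of what the source reports. "The series", "measured", "known", "first", "only" and "open" are said of these compounds alone.

Measured in a functional assay on MCF7 cells (Homo sapiens) for antiproliferative activity, read by MTT assay, with a stated time of 48 h; a lower number here means a stronger inhibitor, a higher number a weaker inhibitor:
- Compound 1 `COc1cc(-c2nnc3c(OCC(F)(F)F)cc(-c4ccc5c(ccn5C)c4)cn23)cc(OC)c1OC`: 382 nM
- Compound 2 `COc1cc(-c2nnc3c(OC4CC4)cc(-c4ccc5c(ccn5C)c4)cn23)cc(OC)c1OC`: 118 nM

Of these two compounds, compound 2 has the lower number, 118 nM, and so stands as the stronger inhibitor in this assay. The next step leads to compound 3 `CCCN1CC(Oc2cc(-c3ccc4c(ccn4C)c3)cn3c(-c4cc(OC)c(OC)c(OC)c4)nnc23)C1`, which keeps the shared core and changes only the group on an oxygen on an aromatic ring: 1-propylazetidin-3-yl in place of cyclopropyl on an oxygen on an aromatic ring. In words, 1-propylazetidin-3-yl sits in place of cyclopropyl.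

Among the compounds with values here, only one measured step bears on this change, since it concerns the same oxygen: a 3.2-fold lower number from compound 1 to compound 2 (0.51 log units; beyond the scatter). That step, which put cyclopropyl in place of 2,2,2-trifluoroethyl, was modest but beyond the scatter. It shows that the number responds to the group at this place, though only moderately. Neither measured compound carries a four-membered ring with a hetero atom, so the data do not fix the direction. Within the data shown here, a step of similar modest size is expected, leaning towards a higher number, as compound 2 holds the lowest value so far at 118 nM. The expected change is a 1.9-fold higher number from compound 2 to compound 3 (0.27 log units; within the scatter). The estimated value for compound 3 is 220 nM, with an expected range of 70 nM to 700 nM.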

Compound 3, half-maximal inhibitory concentration: 378 nM
Compound 3: middle estimate off by 1.7-fold (0.24 log units), on the low side; the range from low to high includes it.
By their numbers in this assay, from the lowest: compound 2; then compounds 3 and 1 (each within the scatter of the next).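

In this assay, a change away from cyclopropyl on this oxygen has now been seen from a second direction: a 3.2-fold higher number from compound 2 to compound 3 (0.51 log units; beyond the scatter) in this series, so a larger group carrying a four-membered non-aromatic ring with 1 hetero atom does not match cyclopropyl here. Set against 2,2,2-trifluoroethyl, that same group gives a 1.0-fold lower number from compound 1 to compound 3 (0.00 log units; within the scatter) and so cannot be told apart from it, even though the two groups differ in their atoms, with 1-propylazetidin-3-yl bringing 1 hydrogen-bond acceptor and 7 heavy atoms. Among these three compounds, only cyclopropyl stands apart, and no measurement at hand accounts for this.

Going by these compounds, it remains open how much of the step from cyclopropyl belongs to the propyl chain on 1-propylazetidin-3-yl, and whether a methyl group or a longer chain in its place would shift the number. On these data alone, it also remains open how a cyclobutyl group or an ethyl group on this oxygen would compare with cyclopropyl.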